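Compound 1 to compound 3: chloro for fluoro

The source may report more compounds than this note shows. Statements on the series, on what has been measured and on what is new or still open speak of the compounds shown alone.

- compound 1 `O=C(CCCCCCn1cc(Nc2ncc(Cl)c(Nc3ccc(F)cc3)n2)cn1)NO`: 500 nM
- compound 2 `O=C(CCCCCn1cc(Nc2ncc(Cl)c(Nc3ccc(F)cc3)n2)cn1)NO`: 420 nM

These values come from a functional assay on K562 cells (Homo sapiens) for antiproliferative activity, read by MTT assay, with a stated time of 48 h; a lower number here means a stronger inhibitor, a higher number a weaker inhibitor. Among the compounds with values here, compound 1 has only one neighbour in this small set, and the two lie within the scatter of each other, so compound 1 holds no distinct place on the numbers.

Compound 3 `O=C(CCCCCCn1cc(Nc2ncc(Cl)c(Nc3ccc(Cl)cc3)n2)cn1)NO` keeps the chain of compound 1 and differs in one place: chloro in place of fluoro on an aromatic carbon. This is chloro in place of fluoro on an aromatic carbon, para to a large group.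

Within the data shown here, the only measured step is a 1.2-fold lower number from compound 1 to compound 2 (0.08 log units; within the scatter). Among the measured compounds shown here, it is a change in the chain, so it bears on this halogen swap only indirectly, and no measured step covers the swap itself. A step beyond the scatter is therefore not expected, though the data cannot exclude one.

The expected result is a 1.1-fold lower number from compound 1 to compound 3 (0.05 log units; within the scatter). Compound 3 is estimated at 450 nM, with an expected range of 180 nM to 1100 nM.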

Compound 3, half-maximal inhibitory concentration: 320 nM
For compound 3 the middle estimate is 1.4-fold (0.15 log units) above the measured one; measured number inside the range.
By their numbers in this assay, from the lowest: compounds 3, 2 and 1 (each within the scatter of the next).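

In this assay, within the data shown here, the first change on the aromatic ring, chloro in place of fluoro on an aromatic carbon para to a large group, gives a 1.6-fold lower number from compound 1 to compound 3 (0.19 log units; within the scatter). The earlier step concerned only the chain, whereas this one shows that on the chain of compound 1 the two halogens cannot be told apart at this position. That reading rests on a single pair, so it says nothing about a wider range of groups there. No supporting data on hand explain this result.

Going by these compounds, whether methoxy, trifluoromethyl or a plain hydrogen on this carbon would give a step beyond the scatter remains open. Also open, on these data alone, is whether chloro would read the same on the chain of compound 2.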